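Swapping the side chain on the imine nitrogen of compound 2

The source may hold more compounds than are shown below. What is called first, only, known or untested is meant among the compounds shown, and "the series" means these compounds.

Measured so far:
compound 1 `CN(C)CC/N=c1\c(O)c(O)\c1=N/C/C=C\COc1csc(CN2CCCCC2)c1` gives 0.35 ug/mL
compound 2 `CC(C)/N=c1\c(O)c(O)\c1=N/C/C=C\COc1csc(CN2CCCCC2)c1` gives 0.78 ug/mL

In a functional assay for antagonist activity at histamine H2 receptor (Cavia porcellus) (a higher number here means a weaker inhibitor, a lower number a stronger inhibitor), compound 2 stands with the highest number of the two measured, its nearest neighbour being compound 1. Within the data shown here, the only measured step that bears on the next change is a 2.2-fold higher number from compound 1 to compound 2 (0.35 log units; beyond the scatter), a modest rise. Compound 3 `COCC/N=c1\c(O)c(O)\c1=N/C/C=C\COc1csc(CN2CCCCC2)c1` differs from compound 2 by 2-methoxyethyl in place of isopropyl on a double-bonded nitrogen. The entering group resembles the chain of compound 1 in length, so a small move back toward the number of compound 1 is expected, as a 1.4-fold lower number from compound 2 to compound 3 (0.15 log units; within the scatter), though within the scatter. Compound 3 is estimated at 0.55 ug/mL, between 0.25 ug/mL and 1.2 ug/mL.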

Compound 3, half-maximal inhibitory concentration: 0.48 ug/mL
For compound 3 the middle estimate is 1.1-fold (0.06 log units) above the measured one, within the range that was stated.
By their numbers in this assay, from the lowest: compounds 1, 3 and 2 (each within the scatter of the next, the first and the last beyond it).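

In this assay, 2-methoxyethyl in place of isopropyl gives a 1.6-fold lower number from compound 2 to compound 3 (0.21 log units; within the scatter), while methoxy in place of dimethylamino gives a 1.4-fold higher number from compound 1 to compound 3 (0.14 log units; within the scatter), so compound 3 cannot be told apart from either neighbour. The dimethylamino group of compound 1 is therefore not shown to be needed on this chain, even though compound 1 and compound 2 differ beyond the scatter. Nothing available explains these numbers. Still open, from the compounds shown here alone, is whether a longer chain, a primary amine or a carboxylic acid on this nitrogen would shift the number beyond the scatter.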